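Swapping a cyclohexyl for a furan ring on the side chain

A few compounds are considered here, and "the series" means these few. Any claim that something is new, unique, unknown or untested is made for them only; others in the source may bear on it.

Compound 1: `CCCSc1nc(Cl)c2c(n1)N(CC1CCCCC1)C(C(=O)N1CCN(C)CC1)N2`, 12800 nM
Compound 2: `CCCSc1nc(Cl)c2c(n1)N(Cc1ccccc1)C(C(=O)NCC(C)C)N2`, > 64000 nM

Of the compounds shown here, two sharing one core have been measured in a functional assay on PC-3 cells (Homo sapiens) for antiproliferative activity, read by MTT assay, with a stated time of 72 h; on this read-out lower numbers stand for stronger inhibition and higher numbers for weaker inhibition. For the measured compounds named here, compound 1 gives 12800 nM, the only plain number recorded. Compound 2 gives > 64000 nM, which is a limit of the assay rather than a measured number. So compound 1 stands as the sole numeric point, alongside (the limit of > 64000 nM in this assay, at which 1 of the 2 values shown sits); no step between the two measured compounds is given, and the two differ in more than one place.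

Compound 3 is `CCCSc1nc(Cl)c2c(n1)N(Cc1ccco1)C(C(=O)N1CCN(C)CC1)N2`, not yet tested. It differs from compound 1 by furan-2-yl in place of cyclohexyl on a saturated chain carbon bound to a nitrogen on an aromatic ring in a ring. A saturated ring leaves and a small aromatic ring with an oxygen enters at the same point of attachment.

Going by the values given here, with no measured step to lean on, the expectation is a small move, if any, and not clearly beyond the usual scatter. From compound 1 to compound 3 the step is estimated as a 1.3-fold higher number from compound 1 to compound 3 (0.10 log units; within the scatter). Compound 3 is therefore expected to show 16000 nM, within a range from 4000 nM to 60000 nM.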

Compound 3, half-maximal inhibitory concentration: 11400 nM
Compound 3: the middle estimate sits 1.4-fold (0.15 log units) above what was measured, within the range that was stated.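

For the compounds shown here, the first readable step at this position, in this assay, is a 1.1-fold lower number from compound 1 to compound 3 (0.05 log units; within the scatter). The six-membered non-aromatic ring of cyclohexyl and the five-membered aromatic ring of furan-2-yl, which brings an oxygen and a hydrogen-bond acceptor, cannot be told apart by this measurement when placed on a saturated chain carbon bound to a nitrogen on an aromatic ring in a ring, so within this pair neither the aromatic character nor the added oxygen comes with a readable difference in antiproliferative activity. Nothing among the measurements shown offers a reason for this match between the two groups.

As far as these compounds go, the pair speaks only for these two uncharged rings, so it remains open how this position would respond to a group of another kind, such as an amine, a carboxylic acid or a longer chain like n-hexyl. Compound 1 and compound 3 also share everything else on the core, which leaves open whether cyclohexyl and furan-2-yl would still match if the rest of the molecule carried different groups.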